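Methoxy to Amino, Repeated on a Second Core

A few compounds are considered here, and "the series" means these few. Any claim that something is new, unique, unknown or untested is made for them only; others in the source may bear on it.

Compound 1 `COC(=O)c1cccc(NC(=O)c2cc3cc([N+](=O)[O-])ccc3o2)c1` and compound 2 `NC(=O)c1cccc(NC(=O)c2cc3cc([N+](=O)[O-])ccc3o2)c1` share one core and differ in a single place: amino in place of methoxy on a carbonyl carbon. In a physicochemical assay for solubility (a higher number here means a more soluble compound, a lower number a less soluble compound), compound 1 gives 25 ug/mL, and compound 2 gives 20 ug/mL, so this change brought a 1.3-fold lower number from compound 1 to compound 2 (0.10 log units; within the scatter).

Compound 3 `COC(=O)c1cccc(NC(=O)c2cc3cc([N+](=O)[O-])ccc3s2)c1` carries the methoxycarbonyl group of compound 1 on a different core; the difference between the two cores is not broken down here. In this assay compound 3 gives 25 ug/mL, the same number as compound 1 at the digits reported.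

Compound 4 `NC(=O)c1cccc(NC(=O)c2cc3cc([N+](=O)[O-])ccc3s2)c1` stands to compound 3 as compound 2 stands to compound 1: amino in place of methoxy on a carbonyl carbon. The place, a carbonyl carbon whose other neighbours are aromatic carbon, reads the same in both pairs, so this is the same change, now made on the core of compound 3.

Since compound 1 and compound 3 give the same number, the step from compound 3 to compound 4 is expected to be a 1.3-fold lower number from compound 3 to compound 4 (0.10 log units; within the scatter), resting on a 1.3-fold lower number from compound 1 to compound 2 (0.10 log units; within the scatter). Compound 4 is therefore estimated at 20 ug/mL, with a range of 10 ug/mL to 40 ug/mL.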

Compound 4, solubility: 25 ug/mL
Estimate against measurement, compound 4: 1.3-fold (0.10 log units) below; the measured number falls inside the stated range.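

In this assay the step on the core of compound 3 reads no change at the digits printed from compound 3 to compound 4 (within the scatter), and the step on the core of compound 1 reads a 1.3-fold lower number from compound 1 to compound 2 (0.10 log units; within the scatter); in both pairs, amino in place of methoxy on a carbonyl carbon stays within the scatter. This shows that the two cores agree in this limited sense: neither step can be told apart from the ordinary spread of repeated measurements. It does not show that the change is without consequence in general, as a small real difference could lie hidden inside the scatter, and two pairs are a thin base for a rule about the series, while no measurement given here speaks to why the numbers fall where they do.

The compounds shown leave open whether a carboxylic acid, a dimethylamino group or a longer chain such as ethoxy on the same carbonyl carbon would give a step beyond the scatter. They also leave open whether amino in place of methoxy would read the same way on a third core.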